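Swapping the Aryl Group on a Saturated Ring Carbon

A few compounds are considered here, and "the series" means these few. Any claim that something is new, unique, unknown or untested is made for them only; others in the source may bear on it.

Of the compounds shown here, two have been measured so far, both built on the same core. Compound 1 `COc1cc(C2=NN(C(C)=O)C(c3cc(Cl)cc(Cl)c3)O2)cc(OC)c1OC` bears a 3,5-dichlorophenyl on a saturated ring carbon, and in a functional assay on PC-3 cells (Homo sapiens) for antiproliferative activity, read by MTT assay, tested at 1 uM (on this read-out lower numbers stand for a weaker effect and higher numbers for a stronger effect at the one concentration tested), compound 1 gives 52.7%. Within the data shown here, compound 2 `COc1cc(C2=NN(C(C)=O)C(c3ccc(C(F)(F)F)cc3)O2)cc(OC)c1OC` carries a 4-(trifluoromethyl)phenyl at that place instead; in this assay compound 2 gives -11%, the lowest of the two numbers, with the single measured step of a number 63.7 percentage points lower from compound 1 to compound 2 (beyond the scatter) separating it from compound 1.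

Compound 3 `COc1cc(C2=NN(C(C)=O)C(c3cccc(F)c3)O2)cc(OC)c1OC` is not yet measured. It differs from compound 2 in one place: 3-fluorophenyl in place of 4-(trifluoromethyl)phenyl on a saturated ring carbon. Among the measured compounds shown here, the only step that bears on this change is the one from compound 1 to compound 2, which was large and downward when the 3,5-dichlorophenyl gave way to the 4-(trifluoromethyl)phenyl. Compound 3 returns to a phenyl carrying only a halogen, though one fluorine rather than two chlorines, so part of that loss is expected to come back. A step upward beyond the scatter is expected for compound 3, a number 36 percentage points higher from compound 2 to compound 3 (beyond the scatter). For compound 3 in this assay the estimate is 25%, with a range from -10% to 60%.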

Compound 3, a percentage reported as inhibition, at one concentration (the size of the read-out at that concentration, not a potency): 16.5%
Estimate against measurement, compound 3: 8.5 percentage points above; low and high end bracket the measured number.
By their numbers in this assay, from the lowest: compound 2; then compound 3; then compound 1.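

In this assay, this position on the saturated ring carbon now shows three separate levels rather than two. Moving to the 3-fluorophenyl gives a number 27.5 percentage points higher from compound 2 to compound 3 (beyond the scatter), so the very low reading of the 4-(trifluoromethyl)phenyl is not shared by every other aryl group tried here. Yet the change from the 3,5-dichlorophenyl to the 3-fluorophenyl gives a number 36.2 percentage points lower from compound 1 to compound 3 (beyond the scatter), which shows that a phenyl carrying only halogen does not by itself reach the level of the dichloro compound, and nothing available here explains why either step occurs.

The 3-fluorophenyl differs from the 3,5-dichlorophenyl in both the kind and the number of its halogens, so these compounds cannot separate the effect of fluorine against chlorine from that of one substituent against two. A 3-chlorophenyl at this place would help pull those two changes apart, while a phenyl bearing a methoxy group or an amine would show whether anything other than halogen can be tolerated there.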